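Iodinated thiophene variant of compound 1: expected cytotoxicity

The compounds below may be only part of what the source reports. "The series", "measured", "known", "first", "only" and "open" are said of these compounds alone.

Among the compounds with values here, compound 1 `O=C(/C=C/c1ccc(N2CCCCC2)cc1)c1ccsc1` gives 32100 nM in an ADME assay on CCRF-CEM cells (Homo sapiens) for cytotoxicity, with a stated time of 5 days (a higher number here means a weaker inhibitor, a lower number a stronger inhibitor), the highest of the three numbers measured so far. Compound 2 `Cc1ccsc1C(=O)/C=C/c1ccc(N2CCCCC2)cc1` gives 9900 nM and compound 3 `Cc1cc(C(=O)/C=C/c2ccc(N3CCCCC3)cc2)c(C)s1` gives 16600 nM. Among these, a 3.2-fold lower number from compound 1 to compound 2 (0.51 log units; beyond the scatter) is the only step beyond the scatter; a 1.9-fold lower number from compound 1 to compound 3 (0.29 log units; within the scatter) and a 1.7-fold higher number from compound 2 to compound 3 (0.22 log units; within the scatter) both stay within it.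

Compound 4 `O=C(/C=C/c1ccc(N2CCCCC2)cc1)c1ccc(I)s1` differs from compound 1 in one place: 5-iodothiophen-2-yl in place of thiophen-3-yl on a carbonyl carbon. Within the data shown here, compound 2, carrying 3-methylthiophen-2-yl, is the closest precedent, and its step from compound 1 was modest. Compound 3 shows that adding methyl groups to the ring of compound 1 left the number within the scatter. Iodine on the ring has no precedent in the series, so the range must stay wide. A modest lower number is expected for compound 4 in this assay, a 2.5-fold lower number from compound 1 to compound 4 (0.39 log units; beyond the scatter). Compound 4 is therefore estimated at 13000 nM in this assay, with a range from 5000 nM to 35000 nM.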

Compound 4, half-maximal inhibitory concentration: 22000 nM
Beside the measured number, compound 4's estimate is 1.7-fold (0.23 log units) below it; measured number inside the range.
By their numbers in this assay, from the lowest: compounds 2, 3, 4 and 1 (each within the scatter of the next, the first and the last beyond it).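

Iodine on the ring does not move the number away from the unsubstituted ring in this assay (a 1.5-fold lower number from compound 1 to compound 4 (0.16 log units; within the scatter)), and 5-iodothiophen-2-yl also stays level with 2,5-dimethylthiophen-3-yl (a 1.3-fold higher number from compound 3 to compound 4 (0.12 log units; within the scatter)). Only 3-methylthiophen-2-yl now stands apart from 5-iodothiophen-2-yl (a 2.2-fold higher number from compound 2 to compound 4 (0.35 log units; beyond the scatter)), so a thiophen-2-yl attachment alone does not carry the step seen with compound 2, and compound 4 is the case against that reading. No measured evidence accounts for this difference between the two groups.

The compounds shown leave open how unsubstituted thiophen-2-yl or 5-methylthiophen-2-yl would read in this assay, which would separate the attachment from the substituent. Also open, going by these compounds, is whether a thiophene carrying an amine or a carboxylic acid on this carbonyl carbon would move the number beyond the scatter from compound 1.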